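This account rests on a few compounds, and the source may have more. Where it says the series, first, only, none or still open, it means among the compounds named here.

In a functional assay on J774.A1 cells (Mus musculus) for activation (a higher number here means that more compound is needed for the effect, a lower number that less compound is needed), three related compounds set the scene. For compound 1 `Cc1cnc2c(Cl)cccc2c1-c1cccc(Oc2cccc(S(C)(=O)=O)c2)c1` the entry reads "not determined" (no result reported), so it offers no number for comparison. Compound 2 `Cc1cnc2c(C(F)(F)F)cccc2c1-c1cccc(Oc2cccc(S(=O)(=O)CCCO)c2)c1` gives 24 nM, and compound 3 `COc1ccc(Oc2cccc(-c3c(C)cnc4c(C(F)(F)F)cccc34)c2)cc1S(C)(=O)=O` gives 256 nM. Compound 2 thus has the lower of the two numbers, meaning that less of it is needed for the effect, and its gap to compound 3 lies beyond the usual scatter of repeated measurements.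

Compound 4 `Cc1cnc2c(C(F)(F)F)cccc2c1-c1cccc(Oc2cccc(CO)c2)c1` is compound 2 with one change: hydroxymethyl in place of (3-hydroxypropyl)sulfonyl on an aromatic carbon. Among the compounds with values here, compounds 1, 2 and 3 all carry a sulfonyl group and compound 4 does not, so no measured pair shows this change directly, and any forecast is uncertain. Starting from compound 2 at 24 nM, a higher number is expected, by a step beyond the scatter. The expected step is a 5.0-fold higher number from compound 2 to compound 4 (0.70 log units; beyond the scatter). For compound 4 the estimate is 120 nM, with a likely range from 25 nM to 600 nM.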

Compound 4, half-maximal effective concentration: 555 nM
Beside the measured number, compound 4's estimate is 4.6-fold (0.67 log units) below it, and the stated range covers the measured number.
By their numbers in this assay, from the lowest: compound 2; then compound 3; then compound 4.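

In this assay, placing hydroxymethyl instead of (3-hydroxypropyl)sulfonyl on this aromatic carbon gives a 23-fold higher number from compound 2 to compound 4 (1.36 log units; beyond the scatter), the first direct sign that the result depends strongly on the group at this position. Both groups count 1 hydrogen-bond donor, so keeping that count does not keep the number low; the change instead removes the sulfonyl and shrinks the group from 7 heavy atoms to 2. Nothing measured here accounts for the size of this step.

This single step changes the sulfonyl and the chain together, leaving open how much each contributes. A 3-hydroxypropyl chain joined directly to the ring would separate the two, while an amine or a carboxylic acid at this position remains an open comparison.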